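The compounds below may be only part of what the source reports. "The series", "measured", "known", "first", "only" and "open" are said of these compounds alone.

Working notes on the sulfamate series. Compound 1 `CN(C)CCN(CCN(C)C)c1ccc(C(=O)N2CCc3ccc(OS(N)(=O)=O)cc3C2)cc1` has been measured in an assay on HEK293 cells for inhibition of Steryl-sulfatase (Homo sapiens), tested at 0.1 uM; a lower number here means a weaker effect, a higher number a stronger effect of the compound at the concentration tested; there compound 1 gives 3.8%, the second highest of the three numbers. Compound 3 `NS(=O)(=O)Oc1ccc2c(c1)CN(C(=O)c1cccc(N3CCCCC3)c1)CC2` gives 1%, within the scatter of compound 1. Compound 2 `NS(=O)(=O)Oc1ccc2c(c1)CN(C(=O)c1cccc(N(Cc3ccccc3)Cc3ccco3)c1)CC2` gives 27.5%, beyond the scatter and well above compound 1. Compound 4 `CCN(Cc1ccccc1)c1ccc(C(=O)N2CCc3ccc(OS(N)(=O)=O)cc3C2)cc1` has not yet been measured. It differs from compound 1 in one place: benzyl(ethyl)amino in place of bis(2-(dimethylamino)ethyl)amino on an aromatic carbon. Among the measured compounds shown here, no step between measured compounds covers this change. For the measured compounds named here, the only guide is that compound 2, the one compound carrying a benzyl group, gives 27.5%. A modest upward step is therefore expected, a number 10.2 percentage points higher from compound 1 to compound 4 (beyond the scatter). Compound 4 is expected to give 14%, with a range from 2% to 35%.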

Compound 4, a percentage reported as inhibition, at one concentration (the size of the read-out at that concentration, not a potency): 66.9%
Estimate against measurement, compound 4: 52.9 percentage points below, outside the stated range (above it).
By their numbers in this assay, from the lowest: compounds 3 and 1 (each within the scatter of the next); then compound 2; then compound 4.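

On an aromatic carbon para to a large group, the choice of amine substituent strongly affects the read-out: benzyl(ethyl)amino in place of bis(2-(dimethylamino)ethyl)amino gives a number 63.1 percentage points higher from compound 1 to compound 4 (beyond the scatter) in this assay at this position. The change replaces a group with no ring and 3 hydrogen-bond acceptors by one with a six-membered aromatic ring of carbon only and 1 hydrogen-bond acceptor. No available evidence accounts for the step. The compounds shown do not separate the contribution of the benzyl group from that of the ethyl group. Dibenzylamino and diethylamino at this position would address that question.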